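The source may report more compounds than this note shows. Statements on the series, on what has been measured and on what is new or still open speak of the compounds shown alone.

In a functional assay on SMMC-7721 cells (Homo sapiens) for cytotoxicity, read by MTT assay, with a stated time of 72 h (on this read-out lower numbers stand for stronger inhibition and higher numbers for weaker inhibition), compound 1 `[O-][n+]1nc(NCOCc2ccc(C(F)(F)F)cc2)[n+]([O-])c2ccccc21` gives 780 nM and compound 2 `COCNc1n[n+]([O-])c2ccccc2[n+]1[O-]` gives 2480 nM, so compound 2 holds the higher of the two numbers, a clear gap on this read-out. Compound 3 `CCCCCCCOCNc1n[n+]([O-])c2ccccc2[n+]1[O-]` departs from compound 2 by hexyl in place of hydrogen on a saturated chain carbon bound to an oxygen on a saturated carbon, which reads as methyl to heptyl. Within the data shown here, the only other measured guide is compound 1, with its larger group on the same oxygen, at 780 nM. On that single comparison, a move towards a lower number beyond the scatter is expected in this assay, estimated as a 2.8-fold lower number from compound 2 to compound 3 (0.44 log units; beyond the scatter). For compound 3 the estimated value is 900 nM, with an expected range of 300 nM to 2500 nM.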

Compound 3, half-maximal inhibitory concentration: 3090 nM
Compound 3: middle estimate off by 3.4-fold (0.54 log units), on the low side, outside the stated range (above it).
By their numbers in this assay, from the lowest: compound 1; then compounds 2 and 3 (each within the scatter of the next).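

In this assay the exchange of hydrogen for hexyl on a saturated chain carbon bound to an oxygen on a saturated carbon gives a 1.2-fold higher number from compound 2 to compound 3 (0.10 log units; within the scatter) and so separates the two compounds by no more than the usual scatter. Among these compounds, at this position, then, going from methyl to heptyl leaves the read-out without a clear change, something the earlier compounds could not show. No evidence at hand bears on this result.

Going by these compounds, whether a shorter chain such as propyl, a longer chain such as decyl, or an amine at the chain end would move the number remains open.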